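The compounds below may be only part of what the source reports. "The series", "measured", "known", "first", "only" and "open" are said of these compounds alone.

Compound 1 `CCN(CC)S(=O)(=O)c1ccc(S(=O)(=O)N2CCC[C@@H](C(=O)N3CCC(F)(F)CC3)C2)cc1`, compound 2 `CCN(CC)S(=O)(=O)c1ccc(S(=O)(=O)N2CCC[C@@H](C(=O)N3CCS(=O)(=O)CC3)C2)cc1` and compound 3 `CCN(CC)S(=O)(=O)c1ccc(S(=O)(=O)N2CCC[C@@H](C(=O)N[C@H]3CC[C@H](OC)CC3)C2)cc1` share a core and differ only in the group carried on the carbonyl carbon. In a functional assay on MIA PaCa-2 cells (Homo sapiens) for inhibition, read by MTT assay, with a stated time of 3 days (a higher number here means a weaker inhibitor, a lower number a stronger inhibitor), compound 1 gives 19 nM, compound 2 gives 220 nM and compound 3 gives 2290 nM. Compound 1 thus stands as the strongest inhibitor of the three: the step of a 12-fold higher number from compound 1 to compound 2 (1.06 log units; beyond the scatter) and the step of a 120-fold higher number from compound 1 to compound 3 (2.08 log units; beyond the scatter) both lie well beyond the scatter, as does the step of a 10-fold higher number from compound 2 to compound 3 (1.02 log units; beyond the scatter).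

Compound 4 `CC(C)S(=O)(=O)c1ccc(S(=O)(=O)N2CCC[C@@H](C(=O)N3CCC(F)(F)CC3)C2)cc1` keeps the 4,4-difluoropiperidin-1-yl group of compound 1 and changes the other end of the molecule instead: isopropyl in place of diethylamino on a sulfonyl sulfur. Going by the values given here, none of the measured steps touches this sulfonyl sulfur; all three concern the carbonyl carbon. Among the compounds with values here, there is therefore no measured step that bears on this change, and the expectation rests only on the potency of compound 1 itself. Compound 4 is expected to stay close to compound 1, with a step of a 2.1-fold higher number from compound 1 to compound 4 (0.32 log units; beyond the scatter) that may or may not exceed the scatter. The estimate for compound 4 in this assay is 40 nM, within a range from 10 nM to 200 nM.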

Compound 4, half-maximal inhibitory concentration: 9.1 nM
Compound 4: the middle estimate sits 4.4-fold (0.64 log units) above what was measured; the whole stated range lies above it.
By their numbers in this assay, from the lowest: compound 4; then compound 1; then compound 2; then compound 3.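

Going by these compounds alone, the sulfonyl sulfur, untouched by the earlier compounds, proves open to change: isopropyl in place of diethylamino gives a modest step that lies beyond the scatter (a 2.1-fold lower number from compound 1 to compound 4 (0.32 log units; beyond the scatter)). With the 4,4-difluoropiperidin-1-yl group held constant, the nitrogen and two of the heavy atoms of the diethylamino group can therefore go without any loss of inhibition, so the diethylsulfamoyl group is not required for this level of potency. Nothing measured here accounts for the lower number.

The compounds shown leave open whether a methyl or cyclopropyl group on the sulfonyl sulfur would lower the number further. They also leave open whether isopropyl would give a similar step alongside the 1,1-dioxothiomorpholin-4-yl or (4-methoxycyclohexyl)amino group on the carbonyl carbon.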